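Swapping the aryl on a ring nitrogen: compound 3

This account rests on a few compounds, and the source may have more. Where it says the series, first, only, none or still open, it means among the compounds named here.

Of the compounds shown here, two sharing one core have been measured. Compound 1 `N#Cc1ccc(-n2nc(-c3ccc(C(F)(F)F)cc3O)nc2-c2ccccc2O)cc1` carries a 4-cyanophenyl group on an aromatic nitrogen, and in a functional assay on PC-12 cells (Rattus norvegicus) for cytotoxicity, read by MTT assay, with stated times of 2 h and 24 h, tested at 1 uM (on this read-out higher numbers stand for a stronger effect at the one concentration tested and lower numbers for a weaker effect), compound 1 gives 66.6%. Compound 2 `Oc1cc(C(F)(F)F)ccc1-c1nc(-c2ccccc2O)n(-c2ccccc2F)n1` has a 2-fluorophenyl group there instead; in this assay compound 2 gives 63.4%. The step of a number 3.2 percentage points lower from compound 1 to compound 2 (within the scatter) lies within the scatter. Compound 1 has the higher of the two numbers, but its nearest neighbour, compound 2, sits within the scatter of it, so no ranking can be claimed.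

Compound 3 `Cc1cc(C)cc(-n2nc(-c3ccc(C(F)(F)F)cc3O)nc2-c2ccccc2O)c1` has not been measured. It differs from compound 1 as follows: 3,5-dimethylphenyl in place of 4-cyanophenyl on an aromatic nitrogen. For the measured compounds named here, the only measured step that bears on this change is the exchange of the same group from compound 1 to compound 2, which stayed within the scatter. A similarly small step, with no direction beyond the scatter, is therefore expected here. Compound 3 is estimated to give 63% in this assay, within a range from 50% to 76%. This estimate corresponds to an expected step of a number 3.6 percentage points lower from compound 1 to compound 3 (within the scatter).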

Compound 3, a percentage reported as activity, at one concentration (the size of the read-out at that concentration, not a potency): 76.9%
The estimate for compound 3 lay 13.9 percentage points below the measured number, outside the stated range (above it).
By their numbers in this assay, from the lowest: compounds 2 and 1 (each within the scatter of the next); then compound 3.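

The position on the aromatic nitrogen is not indifferent to its aryl group, as the first two compounds might have suggested: 3,5-dimethylphenyl gives a number a number 10.3 percentage points higher from compound 1 to compound 3 (beyond the scatter) and also a number 13.5 percentage points higher from compound 2 to compound 3 (beyond the scatter) in this assay, both modest steps. The exchange of 4-cyanophenyl for 3,5-dimethylphenyl keeps the six-membered aromatic ring of carbon only and the count of 8 heavy atoms, so the read-out can shift without a change in either. Nothing available explains why this group gives the higher number.

For the compounds shown here, with only three aryl groups compared, it remains open whether both methyl groups are needed or one would do. From the compounds shown here alone, it is also open how an aryl group bearing an amine or a carboxylic acid, or a longer alkyl chain on this nitrogen, would read in this assay.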